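A few compounds are considered here, and "the series" means these few. Any claim that something is new, unique, unknown or untested is made for them only; others in the source may bear on it.

In a functional assay on MCF7 cells (Homo sapiens) for antiproliferative activity, with a stated time of 48 h (on this read-out higher numbers stand for weaker inhibition and lower numbers for stronger inhibition), compound 1 `Cc1cc(=O)c2c(O)cc(OC[C@H]3CO3)cc2o1` gives 22900 nM, compound 2 `Cc1cc(=O)c2c(OC[C@H]3CO3)cc(OC[C@H]3CO3)cc2o1` gives 220000 nM and compound 3 `Cc1cc(=O)c2c(OC[C@@H]3CO3)cc(OC[C@@H]3CO3)cc2o1` gives 46100 nM. Compound 3 therefore lies within the scatter of compound 1 and clearly below compound 2.

Compound 4 `Cc1cc(=O)c2c(OC[C@@H]3CO3)cc(OC[C@H]3CO3)cc2o1` differs from compound 3 by the two compounds have the same atoms and bonds and differ only in configuration as drawn: 1 of 2 stereo elements differ; a stereocentre at a saturated ring carbon is drawn S in compound 3 and R in compound 4. Thus a stereocentre at a saturated ring carbon is drawn S in compound 3 and R in compound 4.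

Going by the values given here, the closest precedent is a 4.8-fold lower number from compound 2 to compound 3 (0.68 log units; beyond the scatter), tied to configuration by the fact that compounds 2 and 3 differ only in the configuration as drawn. Among the compounds with values here, that step inverts both stereocentres, whereas only one changes here. The other measured step, a 9.6-fold higher number from compound 1 to compound 2 (0.98 log units; beyond the scatter), places (oxiran-2-yl)methyl in place of hydrogen on an oxygen on an aromatic ring and involves no change of configuration, so it offers no direct guide.

With one stereocentre moved towards the drawing in compound 2, a higher number in this assay is expected, covering only part of the full inversion step. The expected change is a 2.0-fold higher number from compound 3 to compound 4 (0.29 log units; within the scatter), near the edge of the scatter, and no individual contribution of either stereocentre has been measured. The estimate for compound 4 is 90000 nM, with an expected range from 35000 nM to 230000 nM.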

Compound 4, half-maximal inhibitory concentration: 13900 nM
Compound 4: the middle estimate sits 6.5-fold (0.81 log units) above what was measured; measured number below the stated range.
By their numbers in this assay, from the lowest: compounds 4, 1 and 3 (each within the scatter of the next, the first and the last beyond it); then compound 2.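

In this assay, changing one stereocentre lowers the number from either side, a 3.3-fold lower number from compound 3 to compound 4 (0.52 log units; beyond the scatter) and a 16-fold lower number from compound 2 to compound 4 (1.20 log units; beyond the scatter), so compound 4, with its mixed configuration, does not fall between compound 2 and compound 3. The two stereocentres therefore do not contribute independently, something the inversion of both, a 4.8-fold lower number from compound 2 to compound 3 (0.68 log units; beyond the scatter), could not reveal. Placing (oxiran-2-yl)methyl in place of hydrogen on an oxygen on an aromatic ring also has no fixed outcome, giving a 9.6-fold higher number from compound 1 to compound 2 (0.98 log units; beyond the scatter) with one configuration but a 1.6-fold lower number from compound 1 to compound 4 (0.22 log units; within the scatter) with the other, and this contrast rests on configuration alone: the fact that compounds 2 and 4 differ only in the configuration as drawn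

Still open, as far as these compounds go, is how the mirror image of compound 4 would read, and so whether the gain belongs to this particular pairing of configurations or to any mixed pairing. Also open, from the compounds shown here alone, is whether the oxirane itself matters, which a 2,3-dihydroxypropyl group or a plain propyl chain on the same oxygen would address, and whether any of these numbers reflects more than the antiproliferative read-out in this one cell line.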